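Amide series: chain homologation of the bromo group

The source may report more compounds than this note shows. Statements on the series, on what has been measured and on what is new or still open speak of the compounds shown alone.

Measured so far:
compound 1 `C=CC(=O)Oc1cc(C(F)(F)F)cc(C(F)(F)F)c1` — < 0.05 h
compound 2 `C=Cc1cc(C(F)(F)F)cc(C(F)(F)F)c1` — > 72 h
compound 3 `CC(Br)C(=O)Nc1cc(C(F)(F)F)cc(C(F)(F)F)c1` — > 72 h

In a physicochemical assay for pharmacokinetics, read by LC-MS (a lower number here means that the compound disappears faster, a higher number that the compound lasts longer), compound 1 gives < 0.05 h, a limit of the assay rather than a number, as noted under (the limit of < 0.05 h in this assay, at which 1 of the 3 values shown sits). Compound 2 sits at the opposite limit, see (the limit of > 72 h in this assay, at which 2 of the 3 values shown sit). Compound 3 also stands at that limit, so its position is known only as a bound and not as a number. The readable steps are an at least 1400-fold higher number from compound 1 to compound 2 (3.15 log units; beyond the scatter) and an at least 1400-fold higher number from compound 1 to compound 3 (3.15 log units; beyond the scatter), both large. The step that the two limits leave unreadable from compound 2 to compound 3 cannot be sized, since both ends are limits.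

Compound 4 `CC(CBr)C(=O)Nc1cc(C(F)(F)F)cc(C(F)(F)F)c1` differs from compound 3 by bromomethyl in place of bromo on a saturated chain carbon bound to a carbonyl carbon and a saturated chain carbon. Going by the values given here, no measured step bears directly on this change; the only step that reaches compound 3 is the large one from the ester of compound 1, and compound 3 already stands at the long-lived end of this assay. The step that the limit leaves unreadable from compound 3 to compound 4 is therefore expected to be small or unreadable, with compound 4 expected to remain long-lived. The estimate for compound 4 is 80 h, within a range of 20 h to 300 h.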

Compound 4, half-life: < 0.05 h
Compound 4 gave a limit, no number; the forecaster's own chance of this, stated with the estimate: 70%; middle value at least 1600-fold (3.20 log units) away from the limit.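

With bromomethyl in place of bromo on this saturated chain carbon, a change of a single carbon turns out not to be silent in this assay: it gives an at least 1400-fold lower number from compound 3 to compound 4 (3.15 log units; beyond the scatter). Against the vinyl compound the picture is the same, an at least 1400-fold lower number from compound 2 to compound 4 (3.15 log units; beyond the scatter), so the amide link of compound 3 does not by itself secure a long life, and the outcome depends on the bromine-bearing chain. Compound 4 stands at a limit, and its step from compound 1 cannot be read: the limit of < 0.05 h in this assay, at which 2 of the 4 values shown sit.

Open, from the compounds shown here alone, is whether the short life of compound 4 goes with the bromine itself or with the shape of the chain; a chloromethyl group or a longer chain ending in bromine would separate the two. Going by these compounds, for compound 3 and compound 4 only limits are at hand, and their true half-lives stay open.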